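Swapping Chloro for Methoxy on a Shared Core

The source may hold more compounds than are shown below. What is called first, only, known or untested is meant among the compounds shown, and "the series" means these compounds.

Three compounds share one core and differ at a single aromatic carbon. Compound 1 `CCOc1ccc2nc(Cl)c(/C=C3\SC(=S)NC3=O)cc2c1` carries an ethoxy there, compound 2 `O=C1NC(=S)S/C1=C\c1cc2cc(Cl)ccc2nc1Cl` a chloro, and compound 3 `Cc1cccc2cc(/C=C3\SC(=S)NC3=O)c(Cl)nc12` a methyl. In a toxicity assay on THP-1 cells (Homo sapiens) for cytotoxicity, read by MTT assay, with a stated time of 48 h (on this read-out higher numbers stand for weaker inhibition of growth and lower numbers for stronger inhibition of growth), compound 1 reaches only the assay limit, > 100 ug/mL. Compound 2 likewise reaches only the limit, > 100 ug/mL. Compound 3 also stops at the limit, > 100 ug/mL. The step that the two limits leave unreadable from compound 1 to compound 2 therefore cannot be read. Compound 4 `COc1ccc2nc(Cl)c(/C=C3\SC(=S)NC3=O)cc2c1` differs from compound 2 by methoxy in place of chloro on an aromatic carbon. Given that (the limit of > 100 ug/mL in this assay, at which 3 of the 3 values shown sit), the change is expected to produce no step beyond the scatter, an estimated step that the limit leaves unreadable from compound 2 to compound 4. Compound 4 is thus expected at 120 ug/mL, ranging from 60 ug/mL to 250 ug/mL, most likely again reported only as a limit.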

Compound 4, concentration for 50% growth inhibition: > 100 ug/mL
Compound 4 ended at the assay's limit; the forecaster's own chance of this, stated with the estimate: 80%; the middle value is on the limit's open side.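

No step can be read from compound 2 to compound 4 or from compound 1 to compound 4, because each pair ends at a limit: the limit of > 100 ug/mL in this assay, at which 4 of the 4 values shown sit.

As far as these compounds go, whether chloro, methoxy, ethoxy or methyl on the shared core changes growth inhibition at all stays open.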